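Furan-2-yl for pyrimidin-5-yl at the biaryl position

This account rests on a few compounds, and the source may have more. Where it says the series, first, only, none or still open, it means among the compounds named here.

Measured compounds:
- compound 1, `CCN(c1ccc(C#N)c(Cl)c1)c1cc(-c2cnc3ccccc3c2)ccc1C`: "not determined" (no result reported) in a functional assay on CWR22R cells (Homo sapiens) for antiproliferative activity, read by CCK-8 assay, with a stated time of 6 days; on this read-out lower numbers stand for stronger inhibition and higher numbers for weaker inhibition
- compound 2, `CCN(c1ccc(C#N)c(Cl)c1)c1cc(-c2cncnc2)ccc1C`: > 30000 nM
- compound 3, `CCN(c1cccc(-c2ccccc2)c1)c1ccc(C#N)c(Cl)c1`: "not determined" (no result reported) in this assay

Three compounds share the ethyl-aminobenzonitrile motif, but only compound 2 carries a number of any kind in this assay. Compound 1 and compound 3 have no result. For compound 2 the reported value is a limit of the assay, not a measured number (the limit of > 30000 nM in this assay, at which 1 of the 3 values shown sits); it says only that no half-maximal inhibition was reached within the tested range. Compound 2 therefore stands at the weak end of what this assay can report, and with the other two entries empty there is nothing to rank it against.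

Compound 4, `CCN(c1ccc(C#N)c(Cl)c1)c1cc(-c2ccco2)ccc1C`, is the next compound to be measured. Its change from compound 2 is furan-2-yl in place of pyrimidin-5-yl on an aromatic carbon. The core, the ethyl group on nitrogen, the nitrile, the chlorine and the methyl group all stay as they are.

For the measured compounds named here, no step between measured compounds is available, so the size of the change cannot be read from the series. Since compound 2 sits at a limit, any real number for compound 4 would already count as a move; the step of an at least 2.0-fold lower number from compound 2 to compound 4 (0.30 log units; that floor lies within the scatter) is expected to be modest and toward stronger inhibition, with a fair chance that compound 4 also returns only a limit. The estimate for compound 4 in this assay is 15000 nM, with a range from 3000 nM to 60000 nM.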

Compound 4, half-maximal inhibitory concentration: > 30000 nM
Compound 4 ended at the assay's limit; the forecaster's own chance of this, stated with the estimate: 45%; at least 2.0-fold (0.30 log units) between middle value and limit.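

Compound 2 and compound 4 both end at a limit in this assay, so furan-2-yl in place of pyrimidin-5-yl gives no step that can be read: the limit of > 30000 nM in this assay, at which 2 of the 4 values shown sit.

The compounds shown leave open whether any group at this place on the shared core reaches half-maximal inhibition within the tested range.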